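A few compounds are considered here, and "the series" means these few. Any claim that something is new, unique, unknown or untested is made for them only; others in the source may bear on it.

In a functional assay on PANC-1 cells (Homo sapiens) for inhibition, read by MTT assay, with a stated time of 24 h, tested at 10 uM (on this read-out lower numbers stand for less inhibition and higher numbers for more inhibition at the one concentration tested (going by the name of the read-out)), compound 1 `CCOc1cc(=O)n(CCCO)c2c1CC(CC=C(C)C)C(C)(C)C2` gives 16.6%, compound 2 `CCOc1cc(=O)n(CCCO)c2c1CC(C/C=C(\C)CCC=C(C)C)C(C)(C)C2` gives 0.8%, and compound 3 `CC(C)=CCC/C(C)=C/CC1Cc2c(OCC=C(C)C)cc(=O)n(CCCO)c2CC1(C)C` gives 15.9%. Compound 2 differs from compound 1 by 3-methylbut-2-en-1-yl in place of hydrogen on a saturated chain carbon bound to a double-bonded chain carbon, and this change produced a number 15.8 percentage points lower from compound 1 to compound 2 (beyond the scatter). Compound 3 differs from compound 2 by a 2-methylprop-1-en-1-yl group in place of methyl on a saturated chain carbon bound to an oxygen on an aromatic ring, giving a number 15.1 percentage points higher from compound 2 to compound 3 (beyond the scatter). The difference between the cores of compound 1 and compound 3 is not broken down here. Compound 4 `CC(C)=CCC/C(C)=C/COc1cc(=O)n(CCCO)c2c1CC(C/C=C(\C)CCC=C(C)C)C(C)(C)C2` differs from compound 3 by 3-methylbut-2-en-1-yl in place of hydrogen on a saturated chain carbon bound to a double-bonded chain carbon, the same change as that from compound 1 to compound 2. Compound 4 is therefore expected to show a number 12.9 percentage points lower from compound 3 to compound 4 (beyond the scatter), because in this assay the earlier step was a number 15.8 percentage points lower from compound 1 to compound 2 (beyond the scatter). Compound 4 is estimated at 3%, between 0% and 14%.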

Compound 4, a percentage reported as inhibition, at one concentration (the size of the read-out at that concentration, not a potency): 3.1%
Beside the measured number, compound 4's estimate is 0.1 percentage points below it, within the range that was stated.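

In this assay, 3-methylbut-2-en-1-yl in place of hydrogen on a saturated chain carbon bound to a double-bonded chain carbon gave a number 12.8 percentage points lower from compound 3 to compound 4 (beyond the scatter), and the step carried over from one core to the other: the same change on two cores in this assay, a number 15.8 percentage points lower (beyond the scatter) from compound 1 to compound 2 and a number 12.8 percentage points lower (beyond the scatter) from compound 3 to compound 4, 3 percentage points apart, within the scatter of two such steps. On the core of compound 2, 2,6-dimethylhepta-1,5-dien-1-yl in place of methyl on a saturated chain carbon bound to an oxygen on an aromatic ring gave a number 2.3 percentage points higher from compound 2 to compound 4 (within the scatter). For the compounds shown here, only two pairs support the carry-over, so it holds for these two cores and does not show that the change would behave alike on any other core.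

The compounds shown leave open how a chain ending in an amine or a carboxylic acid would read at that saturated chain carbon. With a single concentration tested, they also leave potency open.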